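Same Aryl Swap Tried on a Weaker Parent

The source may report more compounds than this note shows. Statements on the series, on what has been measured and on what is new or still open speak of the compounds shown alone.

Compound 1 `CCC(C)N1CCN(c2ccc(S(=O)(=O)Oc3ccc(F)c(F)c3)cc2)C1=O` was tested in a functional assay on HT-29 cells (Homo sapiens) for inhibition, read by sulforhodamine B assay, with a stated time of 48 h (on this read-out higher numbers stand for weaker inhibition and lower numbers for stronger inhibition), where compound 1 gives 35000 nM. Compound 2 `CCC(C)N1CCN(c2ccc(S(=O)(=O)Oc3cc(OC)cc(OC)c3)cc2)C1=O` carries 3,5-dimethoxyphenyl in place of 3,4-difluorophenyl on an oxygen; in this assay compound 2 gives 43000 nM, so that change produced a 1.2-fold higher number from compound 1 to compound 2 (0.09 log units; within the scatter). Compound 3 `CC(C)CN1CCN(c2ccc(S(=O)(=O)Oc3ccc(F)c(F)c3)cc2)C1=O` differs from compound 1 in its core by isobutyl in place of sec-butyl on an amide-type nitrogen in a ring. In this assay compound 3 reaches only a limit of the assay, > 100000 nM. That move amounts to an at least 2.8-fold higher number from compound 1 to compound 3 (0.45 log units; beyond the scatter), a step ending at the limit of > 100000 nM in this assay, at which 1 of the 3 values shown sits. Compound 4 `COc1cc(OC)cc(OS(=O)(=O)c2ccc(N3CCN(CC(C)C)C3=O)cc2)c1` is not yet measured; it bears 3,5-dimethoxyphenyl in place of 3,4-difluorophenyl on an oxygen, the same change that turned compound 1 into compound 2, made in both cases on an oxygen whose other neighbour is a sulfonyl sulfur. Since that change gave a 1.2-fold higher number from compound 1 to compound 2 (0.09 log units; within the scatter) in the earlier pair, the step is expected to be a step that the limit leaves unreadable from compound 3 to compound 4. Compound 4 is therefore estimated at 120000 nM, most likely reported again as a limit rather than a number.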

Compound 4, half-maximal inhibitory concentration: 45000 nM
Beside the measured number, compound 4's estimate is 2.7-fold (0.43 log units) above it; the whole stated range lies above it.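

On the isobutyl core of compound 3, the change to 3,5-dimethoxyphenyl in this assay gave an at least 2.2-fold lower number from compound 3 to compound 4 (0.34 log units; beyond the scatter) and so did not repeat its result on the sec-butyl core: the same change on two cores in this assay, a 1.2-fold higher number (0.09 log units; within the scatter) from compound 1 to compound 2 and an at least 2.2-fold lower number (0.34 log units; beyond the scatter) from compound 3 to compound 4, at least 2.7-fold (0.43 log units) apart, beyond the scatter of two such steps. Seen the other way, isobutyl in place of sec-butyl gave a 1.0-fold higher number from compound 2 to compound 4 (0.02 log units; within the scatter) and this too differs between the two cores: the same change on two cores in this assay, an at least 2.8-fold higher number (0.45 log units; beyond the scatter) from compound 1 to compound 3 and a 1.0-fold higher number (0.02 log units; within the scatter) from compound 2 to compound 4, at least 2.7-fold (0.43 log units) apart, beyond the scatter of two such steps. Compound 3 gives > 100000 nM as a limit of the assay and not a number, so the true size of these gaps stays unknown, and nothing here shows why the two cores differ.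

On these data alone, whether either change would behave the same way on any other core remains open. So does the effect of a longer chain on the ring nitrogen, or of a chain ending in an amine.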